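A cyclopropyl amide in place of a benzyl urea

The compounds below may be only part of what the source reports. "The series", "measured", "known", "first", "only" and "open" are said of these compounds alone.

compound 1 `Cc1ccc(-c2nc3ccc(F)cc3s2)cc1N`: > 50000 nM
compound 2 `COc1ccc2nc(-c3ccc(NC(=O)NCc4ccccc4)cc3)sc2c1`: > 50000 nM

Both entries are limits of a functional assay on HL-60 cells (Homo sapiens) for cytotoxicity, read by MTT assay, with a stated time of 2 days (on this read-out lower numbers stand for stronger inhibition and higher numbers for weaker inhibition), rather than numbers. Compound 1 reaches only the limit > 50000 nM. Compound 2 likewise sits at the limit > 50000 nM. Compound 2 therefore stands at the upper edge of what this assay reports, alongside compound 1, as the limit of > 50000 nM in this assay, at which 2 of the 2 values shown sit, records.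

Compound 3 `COc1ccc2nc(-c3ccc(NC(=O)C4CC4)cc3)sc2c1` differs from compound 2 in one place: cyclopropyl in place of benzylamino on a carbonyl carbon. Within the data shown here, no step between measured compounds is available to gauge what such a change does, and neither measured compound provides a number to move from. The expectation for compound 3 is that it remains at or near the limit, with the step of a number no higher from compound 2 to compound 3 (the limit leaves the size open) expected to be none beyond the scatter. Compound 3 is accordingly estimated at 50000 nM, within a range from 8000 nM to 200000 nM.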

Compound 3, half-maximal inhibitory concentration: > 50000 nM
Compound 3: no number, only a limit; the forecaster's own chance of this, stated with the estimate: 75%; the middle value lies on the limit itself.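

In this assay compound 3 gives > 50000 nM as a limit and not a number. Among these compounds, compound 2 also stands at a limit, so no step from compound 2 to compound 3 can be read. From the compounds shown here alone, what cyclopropyl in place of benzylamino on a carbonyl carbon does in this assay stays open, as does any actual number for compounds 1, 2 and 3.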